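The compounds below may be only part of what the source reports. "The series", "measured", "known", "first", "only" and "open" are said of these compounds alone.

Of the compounds shown here, two of one family have been measured in an assay on cell membranes from Cerebral cortex for displacement of a labelled ligand from Sigma non-opioid intracellular receptor 1 (Cavia porcellus), read by scintillation counting, with a stated time of 120 min; a higher number here means a weaker inhibitor, a lower number a stronger inhibitor. Compound 1 `CN(CCCCN1C(=O)CCCc2ccccc21)Cc1ccccc1` gives 9 nM. Compound 2 `CN(CCCCN1C(=O)CSc2ccccc21)Cc1ccccc1` gives 5 nM, the lowest of the two numbers, although its gap to compound 1 lies within the usual scatter of repeated measurements, so the two cannot be told apart. Compound 3 `CN(CCCCN1C(=O)CSc2ccccc21)Cc1ccc(Cl)cc1` is not yet measured; it differs from compound 2 by chloro in place of hydrogen on an aromatic carbon. For the measured compounds named here, no measured pair shows this change, so the step expected in this assay is a 1.3-fold lower number from compound 2 to compound 3 (0.10 log units; within the scatter), small if any and within the scatter. Compound 3 is therefore expected to give about 4 nM, in a range from 1.5 nM to 12 nM.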

Compound 3, inhibition constant: 13 nM
Beside the measured number, compound 3's estimate is 3.3-fold (0.51 log units) below it, outside the stated range (above it).
By their numbers in this assay, from the lowest: compounds 2, 1 and 3 (each within the scatter of the next, the first and the last beyond it).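

Adding chloro to the benzyl group, on the aromatic carbon para to a large group, gives a 2.6-fold higher number from compound 2 to compound 3 (0.41 log units; beyond the scatter) in this assay. For the compounds shown here, this carbon is therefore not indifferent to substitution, although the step is modest and the number stays in the same low range as those of the earlier compounds. Nothing at hand explains the step.

From the compounds shown here alone, whether this step belongs to chloro itself or to any group placed there remains open, and fluoro, methyl or methoxy at the same carbon would separate the two. Also open, going by these compounds, is whether chloro behaves alike on the core of compound 1.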